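Methylating the carbamoyl nitrogen of compound 3

The source may hold more compounds than are shown below. What is called first, only, known or untested is meant among the compounds shown, and "the series" means these compounds.

Among the measured compounds shown here, compound 3 `Cc1ccccc1C(=O)Nc1ccc(S(=O)(=O)NC2CCN(C(N)=O)CC2)c2ccccc12` is the weakest of the three measured members: in an assay on L1.2 cells for binding affinity to C-C chemokine receptor type 8 (Homo sapiens) (a lower number here means a stronger inhibitor, a higher number a weaker inhibitor), compound 3 gives 243 nM, whereas compound 1 `Cc1ccccc1C(=O)Nc1ccc(S(=O)(=O)NC2CCN(C(=O)CCN)CC2)c2ccccc12` gives 11.3 nM and compound 2 `Cc1ccccc1C(=O)Nc1ccc(S(=O)(=O)NC2CCN(C(=O)C3CNC3)CC2)c2ccccc12` gives 1.5 nM. Both steps arriving at compound 3 are large: a 22-fold higher number from compound 1 to compound 3 (1.33 log units; beyond the scatter) and a 160-fold higher number from compound 2 to compound 3 (2.21 log units; beyond the scatter). Compound 4 `CNC(=O)N1CCC(NS(=O)(=O)c2ccc(NC(=O)c3ccccc3C)c3ccccc23)CC1` differs from compound 3 by methyl in place of hydrogen on an amide-type nitrogen. For the measured compounds named here, no measured step touches this nitrogen; the two steps onto compound 3 exchange the whole substituent on the carbonyl carbon, so they bear on it only loosely, and a methyl is neither the 2-aminoethyl of compound 1 nor the azetidin-3-yl of compound 2. For compound 4 in this assay a step within the scatter is expected, a 1.1-fold lower number from compound 3 to compound 4 (0.04 log units; within the scatter), giving an estimated 220 nM between 80 nM and 650 nM.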

Compound 4, inhibition constant: 0.7 nM
For compound 4 the middle estimate is 310-fold (2.50 log units) above the measured one; the measured number lies below the stated range.
By their numbers in this assay, from the lowest: compound 4; then compound 2; then compound 1; then compound 3.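

This nitrogen is far from silent in this assay and a single methyl on it gives a 350-fold lower number from compound 3 to compound 4 (2.54 log units; beyond the scatter) and turns the weakest of the four into the strongest. Methylamino on the carbonyl carbon also outdoes the larger groups with a 2.1-fold lower number from compound 2 to compound 4 (0.33 log units; beyond the scatter) and with a 16-fold lower number from compound 1 to compound 4 (1.21 log units; beyond the scatter) so neither azetidin-3-yl nor 2-aminoethyl is required for a low number in this set. Nothing available accounts for this gain.

Open, going by these compounds, is whether ethylamino or dimethylamino on the same carbonyl carbon would hold the number this low.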